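Amide aryl variation on a shared azo-indole benzamide core

A few compounds are considered here, and "the series" means these few. Any claim that something is new, unique, unknown or untested is made for them only; others in the source may bear on it.

Measured in a functional assay on P388 cells (Mus musculus) for inhibition, read by MTT assay, with a stated time of 72 h; a higher number here means a weaker inhibitor, a lower number a stronger inhibitor:
- compound 1 `O=C(Nc1ccccc1[N+](=O)[O-])c1ccc(/N=N\c2c[nH]c3ccccc23)cc1`: 77900 nM
- compound 2 `Cc1ccccc1NC(=O)c1ccc(/N=N\c2c[nH]c3ccccc23)cc1`: "not active" (no number reported)
- compound 3 `O=C(Nc1ccc(Cl)cc1)c1ccc(/N=N\c2c[nH]c3ccccc23)cc1`: 80000 nM

Compound 1 and compound 3 stand together: a 1.0-fold higher number from compound 1 to compound 3 (0.01 log units; within the scatter), so the two sit within the scatter of each other. Compound 2 returned no number in this assay, so nothing can be placed against it on a scale, only that it gave no measurable inhibition.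

Compound 4 `Cc1cccc(NC(=O)c2ccc(/N=N\c3c[nH]c4ccccc34)cc2)c1` is the next entry, differing from compound 1 in one place: 3-methylphenyl in place of 2-nitrophenyl on an amide-type nitrogen. Within the data shown here, the one measured step that bears on this is the exchange of the aryl group on the amide-type nitrogen from compound 1 to compound 3, which stayed within the scatter. Compound 2, which also carries a methylphenyl on that nitrogen, gave no number, which leaves open that a methyl-bearing aryl may push the series out of range. On balance the expectation for compound 4 is a step of a 1.1-fold higher number from compound 1 to compound 4 (0.04 log units; within the scatter), within the scatter, with a real chance of no number at all. The estimate for compound 4 in this assay is therefore 85000 nM, with a range from 30000 nM to 250000 nM.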

Compound 4, half-maximal inhibitory concentration: 300 nM
Compound 4: middle estimate off by 280-fold (2.45 log units), on the high side; measured number outside the range, below it.
By their numbers in this assay, from the lowest: compound 4; then compounds 1 and 3 (each within the scatter of the next).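

In this assay, the aryl group on the amide-type nitrogen can matter strongly: 3-methylphenyl in place of 2-nitrophenyl gives a 260-fold lower number from compound 1 to compound 4 (2.41 log units; beyond the scatter), and 3-methylphenyl in place of 4-chlorophenyl gives a 270-fold lower number from compound 3 to compound 4 (2.43 log units; beyond the scatter), whereas the earlier exchange gave only a 1.0-fold higher number from compound 1 to compound 3 (0.01 log units; within the scatter). A methylphenyl on this nitrogen therefore does not in itself mean the loss of a measurable number, as compound 2 also carries a methylphenyl there and gave none, while compound 4 gives 300 nM; steps to compound 2 cannot be read, as it has no number. Nothing available bears on the reason for the size of this change.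

Still open, going by these compounds, is whether the low number depends on the methyl group specifically, or whether an ethyl, methoxy or amino group in its place on the phenyl ring would hold it. Also open, on these data alone, is how the plain phenyl amide compares with compound 4, and whether the low number of compound 4 carries over to other cell lines.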